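A Methyl for a Fluoro: Cytotoxicity Expected Unchanged

The source may hold more compounds than are shown below. What is called first, only, known or untested is meant among the compounds shown, and "the series" means these compounds.

Compound 1 `N#Cc1ccc(Nc2nccc(Nc3ccc(-c4ccc(C#N)cc4)c(F)c3)n2)cc1` was tested in a functional assay on MT4 cells (Homo sapiens) for cytotoxicity, read by MTT assay, with a stated time of 5 days; a higher number here means that more compound is tolerated, a lower number that less compound is tolerated. In this assay compound 1 reaches only a limit of the assay, > 271000 nM, and not a number, as the limit of > 271000 nM in this assay, at which 1 of the 2 values shown sits, shows. Among the measured compounds shown here, compound 2 `COc1cc(-c2ccc(C#N)cc2)ccc1Nc1ccnc(Nc2ccc(C#N)cc2)n1` is the only other measured compound. In this assay compound 2 likewise reaches only a limit, > 298000 nM, as the limit of > 298000 nM in this assay, at which 1 of the 2 values shown sits, shows. Compound 1 thus stands where both measured compounds stand, at the top of what was tested. Compound 3 `Cc1cc(Nc2ccnc(Nc3ccc(C#N)cc3)n2)ccc1-c1ccc(C#N)cc1` has not been measured. It differs from compound 1 in one place: methyl in place of fluoro on an aromatic carbon. For the measured compounds named here, no measured step between neighbouring compounds exists to calibrate this change, so the step from compound 1 to compound 3 is estimated at a step that the limit leaves unreadable from compound 1 to compound 3, nothing beyond the scatter. Compound 3 is expected to give about 300000 nM in this assay, between 150000 nM and 600000 nM, and most likely again as a limit rather than a number.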

Compound 3, half-maximal cytotoxic concentration: 12400 nM
Beside the measured number, compound 3's estimate is 24-fold (1.38 log units) above it, and the stated range ends above it.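

In this assay, methyl in place of fluoro gives an at least 21-fold lower number from compound 1 to compound 3 (1.33 log units; beyond the scatter) and so shows that this position, ortho to a 4-cyanophenyl group, is not indifferent to what it carries. The exchange is of one heavy atom for one, with no hydrogen-bond donor or acceptor entering or leaving, and it still brings a number into view where there had been none. The step remains a bound, as compound 1 gives only a limit and not a number: the limit of > 271000 nM in this assay, at which 1 of the 3 values shown sits.

The compounds shown leave open whether the lower number belongs to methyl alone or would also come with chloro, ethyl or an amine at this position. They also leave open what lies behind the step, and whether the same exchange elsewhere on the shared core would do the same.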